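Tert-butyl for (pyridin-2-yl)methyl in compound 4

This account rests on a few compounds, and the source may have more. Where it says the series, first, only, none or still open, it means among the compounds named here.

In a functional assay on a cell-free system (plasma, Homo sapiens), with a stated time of 3 min (on this read-out higher numbers stand for weaker inhibition and lower numbers for stronger inhibition), compound 1 (`O=C(NCc1cc(Cl)ccc1-n1cnnn1)[C@@H]1[C@@H]2C[C@@H]2CN1C(=O)[C@H](O)Cc1ccccn1`) gives 1700 nM and compound 3 (`CC(C)(C)[C@@H](O)C(=O)N1N=CC[C@H]1C(=O)NCc1cc(Cl)ccc1-n1cnnn1`) gives 1400 nM within the scatter of it, while compound 2 (`CC(C)(C)C[C@@H](O)C(=O)N1N=CC[C@H]1C(=O)NCc1cc(Cl)ccc1-n1cnnn1`) gives 590 nM and so inhibits more strongly than either. Going by the values given here, compound 4 (`CC(C)(C)[C@@H](O)C(=O)N1C[C@H]2C[C@H]2[C@H]1C(=O)NCc1cc(Cl)ccc1-n1cnnn1`) keeps the core of compound 1, and tert-butyl in place of (pyridin-2-yl)methyl on a saturated chain carbon bound to a carbonyl carbon and an oxygen on a saturated carbon is the only change.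

Among the compounds with values here, no measured step makes this exchange. The nearest is a 2.4-fold higher number from compound 2 to compound 3 (0.38 log units; beyond the scatter) which also brings in tert-butyl, but in place of neopentyl and on another core, so it bears only indirectly. Compound 3 carries the same tert-butyl and gives 1400 nM on that other core, a number close to that of compound 1. No step beyond the scatter is therefore expected in this assay and a 1.2-fold lower number from compound 1 to compound 4 (0.08 log units; within the scatter) is the estimated change. Compound 4 is estimated at 1400 nM with an expected range from 600 nM to 3300 nM in this assay.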

Compound 4, half-maximal inhibitory concentration: 1200 nM
The estimate for compound 4 lay 1.2-fold (0.07 log units) above the measured number; low and high end bracket the measured number.
By their numbers in this assay, from the lowest: compound 2; then compounds 4, 3 and 1 (each within the scatter of the next).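

Read directly on the core of compound 1, tert-butyl in place of (pyridin-2-yl)methyl gives a 1.4-fold lower number from compound 1 to compound 4 (0.15 log units; within the scatter) in this assay. The earlier compounds shown here showed a change at this place only on another core, whereas here the six-membered aromatic ring and its hydrogen-bond acceptor leave without a step beyond the scatter, on this core and in this read-out. Nothing shown gives a reason for this result.

From the compounds shown here alone, what a carboxylic acid or an amine would give on this saturated chain carbon remains open. Also open, going by these compounds, is whether neopentyl, with which compound 2 gives 590 nM on the other core, would give a number beyond the scatter of compound 4 on the core of compound 1.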